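Geometric isomer step in the acetylated glycoside series

A few compounds are considered here, and "the series" means these few. Any claim that something is new, unique, unknown or untested is made for them only; others in the source may bear on it.

Among the measured compounds shown here, compound 3 `CC(=O)OC[C@H]1O[C@@H](n2cc(CN3C(=O)/C(=C\c4ccc(N(C)C)cc4)c4ccccc43)nn2)[C@H](OC(C)=O)[C@@H](OC(C)=O)[C@@H]1OC(C)=O` stands at the low end of the three numbers so far in a functional assay on HeLa cells (Homo sapiens) for cytotoxicity, read by sulforhodamine B assay, with a stated time of 48 h; a lower number here means a stronger inhibitor, a higher number a weaker inhibitor: compound 3 gives 25000 nM. Compound 1 `CC(=O)OC[C@H]1O[C@@H](n2cc(CN3C(=O)/C(=C/c4ccccc4)c4ccccc43)nn2)[C@H](OC(C)=O)[C@@H](OC(C)=O)[C@@H]1OC(C)=O` gives 37100 nM, a gap within the scatter, while compound 2 `CC(=O)OC[C@H]1O[C@@H](n2cc(CN3C(=O)/C(=C/c4ccc(C)cc4)c4ccccc43)nn2)[C@H](OC(C)=O)[C@@H](OC(C)=O)[C@@H]1OC(C)=O` gives 85600 nM, a gap beyond it. For the measured compounds named here, the one measured step, a 2.3-fold higher number from compound 1 to compound 2 (0.36 log units; beyond the scatter), concerns a substituent on an aromatic carbon and carries no information on geometry. Compound 4 `CC(=O)OC[C@H]1O[C@@H](n2cc(CN3C(=O)/C(=C/c4ccc(N(C)C)cc4)c4ccccc43)nn2)[C@H](OC(C)=O)[C@@H](OC(C)=O)[C@@H]1OC(C)=O` differs from compound 3 thus: the two compounds have the same atoms and bonds and differ only in configuration as drawn: 1 of 6 stereo elements differ; a double bond is drawn Z in compound 3 and E in compound 4. Going by the values given here, no measured pair isolates this change; compounds 1 and 2 carry the E geometry and fall in the same broad range as compound 3. Compound 4 is therefore expected to stay within the scatter of compound 3, the step of a 1.2-fold higher number from compound 3 to compound 4 (0.08 log units; within the scatter) being none beyond scatter. The estimate for compound 4 is 30000 nM, with a range from 10000 nM to 90000 nM.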

Compound 4, half-maximal inhibitory concentration: 26300 nM
Estimate against measurement, compound 4: 1.1-fold (0.06 log units) above; measured number inside the range.
By their numbers in this assay, from the lowest: compounds 3, 4 and 1 (each within the scatter of the next); then compound 2.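

In this assay, the double-bond geometry shows no effect beyond the scatter with dimethylamino on the aromatic carbon, at a 1.1-fold higher number from compound 3 to compound 4 (0.02 log units; within the scatter). Among the E compounds, dimethylamino in place of methyl gives a 3.3-fold lower number from compound 2 to compound 4 (0.51 log units; beyond the scatter), while dimethylamino in place of hydrogen gives a 1.4-fold lower number from compound 1 to compound 4 (0.15 log units; within the scatter), which is within the scatter. Compound 2 therefore stands apart from compound 1 and compound 4.

Going by these compounds, whether geometry is equally silent with hydrogen or methyl at this carbon remains open. So does the effect of a carboxylic acid or a primary amine there, or of free hydroxyl groups in place of the acetates.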